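The source may report more compounds than this note shows. Statements on the series, on what has been measured and on what is new or still open speak of the compounds shown alone.

Compound 1, `c1ccc(-c2nc3ccc[nH]c-3n2)cc1`, gives 8 mg/kg in a functional assay on the whole organism with Canis familiaris (Canis lupus familiaris) as the target; on this read-out higher numbers stand for an effect only at larger amounts of compound and lower numbers for an effect already at smaller amounts. Compound 2, `Cc1cccc(-c2nc3ccc[nH]c-3n2)c1`, gives 2.8 mg/kg in this assay. Compound 3, `c1ccc(-c2nc3cc[nH]cc-3n2)cc1`, gives 2.5 mg/kg in this assay.

Compound 2 differs from compound 1 by methyl in place of hydrogen on an aromatic carbon, and this change brought a 2.9-fold lower number from compound 1 to compound 2 (0.46 log units; beyond the scatter). Compound 3 carries a core with the same atoms as the core of compound 1 but joined differently; the difference between the two cores is not broken down here. Compound 3 and compound 2 give numbers within the usual scatter of each other, while compound 1 stands apart from both.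

Compound 4, `Cc1cccc(-c2nc3cc[nH]cc-3n2)c1`, has not yet been measured. It differs from compound 3 by methyl in place of hydrogen on an aromatic carbon, which is the same change as that from compound 1 to compound 2, made on the core of compound 3. For the measured compounds named here, only one measured instance of this change is available, so the expectation rests on it alone: an expected step of a 2.3-fold lower number from compound 3 to compound 4 (0.36 log units; beyond the scatter) in this assay, somewhat more cautious than the measured one because of a 2.9-fold lower number from compound 1 to compound 2 (0.46 log units; beyond the scatter) being a single observation. Compound 4 is therefore estimated at 1.1 mg/kg in this assay, with a range from 0.5 mg/kg to 2.5 mg/kg.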

Compound 4, dose for half-maximal effect: 1 mg/kg
The estimate for compound 4 lay 1.1-fold (0.04 log units) above the measured number, within the range that was stated.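

On the core of compound 3, methyl in place of hydrogen on an aromatic carbon brought a 2.5-fold lower number from compound 3 to compound 4 (0.40 log units; beyond the scatter) in this assay. Set beside the same change on the core of compound 1, the new step shows no difference in size: the same change on two cores in this assay, a 2.9-fold lower number (0.46 log units; beyond the scatter) from compound 1 to compound 2 and a 2.5-fold lower number (0.40 log units; beyond the scatter) from compound 3 to compound 4, 1.1-fold (0.06 log units) apart, within the scatter of two such steps So, in these two pairs, the change carried over from one core to the other with its size intact, but two pairs do not show that it would hold on any further core, and they say nothing about why the number falls.

The compounds shown leave open whether a longer chain such as ethyl, or a group such as methoxy or chlorine, would act as methyl does at this place on the ring of carbon only, and whether methyl would do the same elsewhere on that ring. They also leave open how an amine or a carboxylic acid there would read in this assay.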